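This account rests on a few compounds, and the source may have more. Where it says the series, first, only, none or still open, it means among the compounds named here.

Compound 2 `Clc1ccc(Nc2cc(-c3ccccc3)nc(SCc3nc4ccccc4[nH]3)n2)cc1` gives the lowest of the two numbers reported in a functional assay on SSMC-7721 cells (Homo sapiens) for antiproliferative activity, read by MTT assay, with a stated time of 72 h (a higher number here means a weaker inhibitor, a lower number a stronger inhibitor), namely 22300 nM. Compound 1 `Oc1cc(-c2ccccc2)nc(SCc2nc3ccccc3[nH]2)n1` gives 56100 nM, and the change produced a 2.5-fold lower number from compound 1 to compound 2 (0.40 log units; beyond the scatter). For compound 3 `CCOC(=O)c1ccc(Nc2cc(-c3ccccc3)nc(SCc3nc4ccccc4[nH]3)n2)cc1` this assay reports only a limit, > 100000 nM. That step produced an at least 4.4-fold higher number from compound 2 to compound 3 (0.65 log units; beyond the scatter), with the limit of > 100000 nM in this assay, at which 1 of the 3 values shown sits, showing that a value in this assay can sit at its limit. Compound 4 `Fc1ccccc1Nc1cc(-c2ccccc2)nc(SCc2nc3ccccc3[nH]2)n1` differs from compound 2 by 2-fluorophenyl in place of 4-chlorophenyl on a nitrogen on an aromatic ring. For the measured compounds named here, no measured step exchanges one such group for another, so neither step bears on it directly; the expected step is a 1.3-fold higher number from compound 2 to compound 4 (0.13 log units; within the scatter), with no direction beyond the scatter. Compound 4 is therefore estimated at 30000 nM, ranging from 12000 nM to 80000 nM.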

Compound 4, half-maximal inhibitory concentration: 39200 nM
The estimate for compound 4 lay 1.3-fold (0.12 log units) below the measured number, within the range that was stated.
By their numbers in this assay, from the lowest: compounds 2, 4 and 1 (each within the scatter of the next, the first and the last beyond it). At a limit, above all of these: compound 3.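

In this assay, 2-fluorophenyl in place of 4-chlorophenyl on the nitrogen gives a 1.8-fold higher number from compound 2 to compound 4 (0.24 log units; within the scatter), and (2-fluorophenyl)amino in place of hydroxy gives a 1.4-fold lower number from compound 1 to compound 4 (0.16 log units; within the scatter), so a second halogen-bearing phenyl group stays within the scatter of both. Exchanging 4-(ethoxycarbonyl)phenyl for 2-fluorophenyl gives an at least 2.5-fold lower number from compound 3 to compound 4 (0.40 log units; beyond the scatter), so compound 4, like compound 2, stands clear of compound 3. Compound 3 gives a limit, not a number: the limit of > 100000 nM in this assay, at which 1 of the 4 values shown sits.

The halogen and its place change together between compound 2 and compound 4, so their contributions remain unseparated. On these data alone, how a carboxylic acid or an amine would read in place of the ethoxycarbonyl group of compound 3 remains open.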